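The source may report more compounds than this note shows. Statements on the series, on what has been measured and on what is new or still open speak of the compounds shown alone.

Compound 3 `O=C(CCc1ccc(Oc2ccccc2)cc1)c1ncc(I)o1` is measured in an assay for inhibition of Fatty-acid amide hydrolase 1 (Rattus norvegicus) (a higher number here means a weaker inhibitor, a lower number a stronger inhibitor), where compound 3 gives 10 nM. Among the three compounds, this is the second highest number: compound 2 `O=C(CCc1ccc(COc2ccccc2)cc1)c1ncc(-c2cccc(-c3nnn[nH]3)n2)o1` gives 21 nM, and compound 1 `N#Cc1cccc(-c2cnc(C(=O)CCc3ccc(COc4ccccc4)cc3)o2)n1` gives 0.56 nM. Within the data shown here, the one single-change step known, a 38-fold higher number from compound 1 to compound 2 (1.57 log units; beyond the scatter), concerns a different part of the molecule.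

Compound 4 `O=C(CCc1ccc(COc2ccccc2)cc1)c1ncc(I)o1` differs from compound 3 by phenoxymethyl in place of phenoxy on an aromatic carbon. Among the measured compounds shown here, no measured step isolates this change; compounds 1 and 2 both carry the phenoxymethyl group, but they also differ from compound 3 elsewhere, so only their values can be compared. A step of a 2.0-fold lower number from compound 3 to compound 4 (0.30 log units; within the scatter) is therefore expected, near the scatter. Compound 4 is estimated at 5 nM, in the range 1.5 nM to 20 nM.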

Compound 4, inhibition constant: 4 nM
For compound 4 the middle estimate is 1.3-fold (0.10 log units) above the measured one; the measured number falls inside the stated range.
By their numbers in this assay, from the lowest: compound 1; then compound 4; then compound 3; then compound 2.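

The step of a 2.5-fold lower number from compound 3 to compound 4 (0.40 log units; beyond the scatter) in this assay gives phenoxymethyl in place of phenoxy its own measured effect, with iodo held constant. With phenoxymethyl now held constant, a 7.1-fold higher number from compound 1 to compound 4 (0.85 log units; beyond the scatter) places 6-cyanopyridin-2-yl on the stronger side of iodo, while a 5.3-fold lower number from compound 2 to compound 4 (0.72 log units; beyond the scatter) places 6-(1H-tetrazol-5-yl)pyridin-2-yl on the weaker side. No measurement shown here explains why these steps go as they do. From the compounds shown here alone, whether phenoxymethyl keeps its advantage over phenoxy alongside 6-cyanopyridin-2-yl remains open. Going by these compounds, how a carboxylic acid in place of the nitrile would compare also remains open.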